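Pyrimidin-5-yl in Place of Pyridin-4-yl: An Expected Step

This account rests on a few compounds, and the source may have more. Where it says the series, first, only, none or still open, it means among the compounds named here.

Compound 1 `COc1ccccc1S(=O)(=O)/C=C/c1ccccn1`: 100%
Compound 2 `COc1ccccc1S(=O)(=O)/C=C/c1ccncc1`: 96.8%

Of the compounds shown here, two have been measured in an ADME assay on BV-2 cells (Mus musculus) for cytotoxicity, with a stated time of 24 h, tested at 10 uM; a lower number here means a stronger effect, a higher number a weaker effect of the compound at the concentration tested. Compound 1 gives 100%, and compound 2 gives 96.8%. On these two numbers compound 2 stands beside compound 1, with the step of a number 3.2 percentage points lower from compound 1 to compound 2 (within the scatter); that step is within the scatter, so the two compounds are not told apart by this assay.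

Compound 3 `COc1ccccc1S(=O)(=O)/C=C/c1cncnc1` has not yet been measured. It differs from compound 2 in one place: pyrimidin-5-yl in place of pyridin-4-yl on a double-bonded chain carbon bound to a double-bonded chain carbon. Within the data shown here, the only measured step that bears on this change is the one from compound 1 to compound 2, where one six-membered aromatic ring with a single nitrogen gave way to another, and it produced no step beyond the scatter, a number 3.2 percentage points lower from compound 1 to compound 2 (within the scatter). Among the measured compounds shown here, a second nitrogen entering the ring is a change of similar scale, and no measured step speaks to it directly. Compound 3 is therefore expected to show no step beyond the scatter in this assay, a number 0.2 percentage points higher from compound 2 to compound 3 (within the scatter), and its value is estimated at 97%, within 85% to 100%.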

Compound 3, a percentage reported as activity, at one concentration (the size of the read-out at that concentration, not a potency): 100%
Beside the measured number, compound 3's estimate is 3 percentage points below it, within the range that was stated.
By their numbers in this assay, from the lowest: compounds 2, 1 and 3 (each within the scatter of the next).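

At this place, on a double-bonded chain carbon bound to a double-bonded chain carbon, the earlier pair had compared only rings with 1 hetero atom. Pyrimidin-5-yl, with 2 hetero atoms and 2 hydrogen-bond acceptors, now extends that comparison in this assay: against pyridin-4-yl the result is a number 3.2 percentage points higher from compound 2 to compound 3 (within the scatter), and against pyridin-2-yl it is no change at the digits printed from compound 1 to compound 3 (within the scatter). The assay therefore does not tell these three rings apart at the concentration tested, whichever pair is read, and nothing measured here offers an account of that outcome.

On these data alone, all three compounds carry a six-membered aromatic ring containing nitrogen, so it remains open whether a plain phenyl ring, or a ring bearing an amine or a carboxylic acid, would also stand within the scatter at this place. Also open, as far as these compounds go, is whether the same holds when the rest of the shared core is changed, since these compounds differ only in this one ring.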